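Extending the amide methyl to ethyl in the lactam series

The compounds below may be only part of what the source reports. "The series", "measured", "known", "first", "only" and "open" are said of these compounds alone.

Going by the values given here, compound 2 `CN1CCN(c2ccc(Nc3ncc4c(n3)N(C3CCCC3)CC(=O)N4C)nc2)CC1` is the reference point of the set: in a functional assay on HCT-116 cells (Homo sapiens) for inhibition, read by MTT assay, with a stated time of 48 h (a lower number here means a stronger inhibitor, a higher number a weaker inhibitor), compound 2 gives 9730 nM, the only actual number among the three results. Compound 1 `CN1CCN(c2ccc(Nc3ncc4c(n3)N(C3CCCC3)CC(=O)N4)nc2)CC1` carries hydrogen where compound 2 carries methyl on the amide-type nitrogen in the ring; in this assay compound 1 reaches only the limit > 30000 nM. Compound 3 `CC1CCN(c2ccc(Nc3ncc4c(n3)N(C3CCCC3)CC(=O)N4C)nc2)CC1` carries 4-methylpiperidin-1-yl in place of 4-methylpiperazin-1-yl; in this assay compound 3 likewise stops at the limit > 30000 nM. The two measured steps are an at least 3.0-fold lower number from compound 1 to compound 2 (0.48 log units; beyond the scatter) and an at least 3.0-fold higher number from compound 2 to compound 3 (0.48 log units; beyond the scatter), and both are sized only against (the limit of > 30000 nM in this assay, at which 2 of the 3 values shown sit).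

Compound 4 `CCN1C(=O)CN(C2CCCC2)c2nc(Nc3ccc(N4CCN(C)CC4)cn3)ncc21` differs from compound 2 by methyl in place of hydrogen on a saturated chain carbon bound to an amide-type nitrogen in a ring. Among the compounds with values here, of the measured steps only the one from compound 1 to compound 2, an at least 3.0-fold lower number from compound 1 to compound 2 (0.48 log units; beyond the scatter), touches this nitrogen, and it shows that the first methyl there lowered the number; nothing in the set shows whether a further carbon on that methyl lowers it again, raises it, or leaves it alone. The working expectation for the step is therefore small, within the scatter, with the chance of a limit kept in view. Compound 4 is expected to give about 10000 nM in this assay, between 3000 nM and 30000 nM. The expected step is a 1.0-fold higher number from compound 2 to compound 4 (0.01 log units; within the scatter).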

Compound 4, half-maximal inhibitory concentration: 16400 nM
Beside the measured number, compound 4's estimate is 1.6-fold (0.21 log units) below it; the measured number falls inside the stated range.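

In this assay, extending methyl to ethyl on the amide-type nitrogen in a ring gives a 1.7-fold higher number from compound 2 to compound 4 (0.23 log units; within the scatter), so this position accepts the extra carbon with no change that can be read, which the hydrogen-to-methyl step alone could not show. Replacing the hydrogen directly with ethyl gives an at least 1.8-fold lower number from compound 1 to compound 4 (0.26 log units; that floor lies within the scatter), whereas the hydrogen-to-methyl step gives an at least 3.0-fold lower number from compound 1 to compound 2 (0.48 log units; beyond the scatter), so only the methyl step clears the scatter even at its floor. Both steps from the hydrogen compound are floors and not full sizes, and their true sizes cannot be read: the limit of > 30000 nM in this assay, at which 2 of the 4 values shown sit.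

From the compounds shown here alone, whether a longer chain such as propyl, a branched isopropyl or a chain ending in an amine on this nitrogen would stay level with the methyl and ethyl groups remains open. Also open, going by these compounds, is whether the ethyl group would hold its place with 4-methylpiperidin-1-yl in place of 4-methylpiperazin-1-yl on the aromatic carbon, since that change appears here only with the methyl group.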